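Swapping the aryl group on a pyrazolopyridine ketone scaffold

The source may report more compounds than this note shows. Statements on the series, on what has been measured and on what is new or still open speak of the compounds shown alone.

In an assay for binding affinity to dual specificity mitogen-activated protein kinase kinase 4 (Homo sapiens), read by KINOMEscan, tested at 100 nM (on this read-out higher numbers stand for a weaker effect at the one concentration tested and lower numbers for a stronger effect), compound 1 `CCCS(=O)(=O)Nc1ccc(F)c(C(=O)c2n[nH]c3ncc(-c4cccc(C)c4)cc23)c1F` gives 15%, compound 2 `CCCS(=O)(=O)Nc1ccc(F)c(C(=O)c2n[nH]c3ncc(-c4cccc(O)c4)cc23)c1F` gives 2.2%, and compound 3 `CCCS(=O)(=O)Nc1ccc(F)c(C(=O)c2n[nH]c3ncc(-c4ccc(Cl)cc4Cl)cc23)c1F` gives 22%. Compound 3 thus shows the highest of the three numbers, though the gap a number 7 percentage points higher from compound 1 to compound 3 (within the scatter) lies within the scatter, while the gap a number 19.8 percentage points higher from compound 2 to compound 3 (beyond the scatter) lies beyond it. Compound 4 `CCCS(=O)(=O)Nc1ccc(F)c(C(=O)c2n[nH]c3ncc(-c4ccc(F)cc4C)cc23)c1F` differs from compound 3 by 4-fluoro-2-methylphenyl in place of 2,4-dichlorophenyl on an aromatic carbon. The step that bears most on this is a number 7 percentage points higher from compound 1 to compound 3 (within the scatter), where one substituted phenyl replaced another without a change beyond the scatter; only the hydroxy-bearing compound 2 moved the number appreciably. Compound 4 is therefore expected to stay close to compound 3, with an estimated step of a number 4 percentage points lower from compound 3 to compound 4 (within the scatter). Compound 4 is estimated at 18%, within a range of 6% to 36%.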

Compound 4, a percentage reported as activity, at one concentration (the size of the read-out at that concentration, not a potency): 14%
Beside the measured number, compound 4's estimate is 4 percentage points above it, and the stated range covers the measured number.
By their numbers in this assay, from the lowest: compound 2; then compounds 4, 1 and 3 (each within the scatter of the next).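

In this assay, replacing 2,4-dichlorophenyl with 4-fluoro-2-methylphenyl leaves the read-out unresolved from its neighbours, with a number 8 percentage points lower from compound 3 to compound 4 (within the scatter) and a number 1 percentage points lower from compound 1 to compound 4 (within the scatter). Compound 2 remains the only one set apart, with a number 11.8 percentage points higher from compound 2 to compound 4 (beyond the scatter), so a different pair of ring substituents on this aromatic carbon did not reproduce the separation seen with 3-hydroxyphenyl. Nothing available here explains these differences.

From the compounds shown here alone, whether an aminophenyl or carboxyphenyl group would match the 3-hydroxyphenyl group remains open. So does whether a hydroxy group elsewhere on this ring would do so.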